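A Benzyl Amide in Place of the Cyclic Amide of Compound 2

The source may hold more compounds than are shown below. What is called first, only, known or untested is meant among the compounds shown, and "the series" means these compounds.

compound 1 `CS(=O)(=O)c1ccc(C(=O)NCC(=O)N(Cc2ccccc2)Cc2ccccc2)cc1[N+](=O)[O-]` — 3600 nM
compound 2 `CS(=O)(=O)c1ccc(C(=O)NCCCC(=O)N2Cc3ccccc3C2)cc1[N+](=O)[O-]` — > 60000 nM
compound 3 `CS(=O)(=O)c1ccc(C(=O)N2CCC(C(=O)N3CCN(c4ccc(F)cc4)CC3)CC2)cc1[N+](=O)[O-]` — > 60000 nM

All three measured compounds share the same core and differ only in the amide portion attached to it. Going by the values given here, in an assay on isolated protein for inhibition of thyroid hormone receptor beta (Homo sapiens), read by fluorescence polarization (on this read-out lower numbers stand for stronger inhibition and higher numbers for weaker inhibition), compound 1 gives 3600 nM, the one genuine number among the three. Compound 2 reaches only the limit of this assay, > 60000 nM, so no number is known for it. Compound 3 likewise stands at the limit, > 60000 nM. Compound 2 therefore sits at the weak end of what is shown, at the limit of > 60000 nM in this assay, at which 2 of the 3 values shown sit, and no step between measured compounds is available to calibrate any single change.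

Compound 4 `CN(Cc1cccc(F)c1)C(=O)CCCNC(=O)c1ccc(S(C)(=O)=O)c([N+](=O)[O-])c1` has not yet been measured. It differs from compound 2 in one place: a group of 10 heavy atoms (8 carbon, 1 nitrogen, 1 fluorine; one six-membered aromatic ring of carbon only) in place of a group of 9 heavy atoms (8 carbon, 1 nitrogen; one five-membered non-aromatic ring with 1 hetero atom, one six-membered aromatic ring of carbon only), on a carbonyl carbon. With compound 2 known only as a limit, the size of the step of an at least 2.0-fold lower number from compound 2 to compound 4 (0.30 log units; that floor lies within the scatter) that the estimate means can only be expected, not derived; a move back toward a measurable value, as compound 1 shows with its open-chain benzyl amide, is expected rather than no change at all. Compound 4 is expected to give about 30000 nM, within a range from 8000 nM to 90000 nM, with a real chance that this assay again reports only a limit.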

Compound 4, half-maximal inhibitory concentration: > 60000 nM
Compound 4 was reported as a limit (the forecaster's own chance of this, stated with the estimate: 45%); middle value at least 2.0-fold (0.30 log units) away from the limit.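

In this assay compound 4 gives > 60000 nM, a limit and not a number. Compound 2 is also known only as a limit, so no step can be read between compound 2 and compound 4. The compounds shown leave open whether (3-fluorobenzyl)(methyl)amino on the carbonyl carbon changes the inhibition of compound 2 at all, and in which direction.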